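Methyl to methoxy on the aroyl arm of an inactive pair

A few compounds are considered here, and "the series" means these few. Any claim that something is new, unique, unknown or untested is made for them only; others in the source may bear on it.

Measured so far:
compound 1, `COc1ccc(C(=O)C2Sc3nnc(-c4cc(OC)c(OC)c(OC)c4)n3NC2c2cccs2)cc1`: > 100000 nM
compound 2, `COc1cc(-c2nnc3n2NC(c2ccco2)C(C(=O)c2ccc(C)cc2)S3)cc(OC)c1OC`: > 100000 nM

Compound 2 was tested in a functional assay on A549 cells (Homo sapiens) for cytotoxicity, read by MTT assay, with a stated time of 48 h (a lower number here means a stronger inhibitor, a higher number a weaker inhibitor), and gives > 100000 nM, which is a limit of the assay and not a number. Compound 1 likewise gives > 100000 nM, again a limit. Compound 2 therefore stands where everything stands here: the limit of > 100000 nM in this assay, at which 2 of the 2 values shown sit. Compound 3 `COc1ccc(C(=O)C2Sc3nnc(-c4cc(OC)c(OC)c(OC)c4)n3NC2c2ccco2)cc1` is not yet measured; it differs from compound 2 by methoxy in place of methyl on an aromatic carbon. Among the compounds with values here, no step between measured compounds is available to calibrate this change, and both measured values sit at the limit, so the expected step that the limit leaves unreadable from compound 2 to compound 3 is none beyond the scatter. On that basis compound 3 is expected to give 150000 nM in this assay, with a range from 50000 nM to 500000 nM, most probably reported once more as a limit rather than a number.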

Compound 3, half-maximal inhibitory concentration: > 100000 nM
Compound 3 gave a limit, no number (the forecaster's own chance of this, stated with the estimate: 85%); the middle value is on the limit's open side.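

Compound 3 gives > 100000 nM, a limit and not a number. No step to compound 3 from compound 2 or compound 1 can be read: the limit of > 100000 nM in this assay, at which 3 of the 3 values shown sit.

The compounds shown leave open whether methoxy in place of methyl, or furan-2-yl in place of thiophen-2-yl, changes the result in this assay.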